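The source may report more compounds than this note shows. Statements on the series, on what has been measured and on what is new or still open speak of the compounds shown alone.

In a functional assay, read by fluorescence and spectrophotometry, with a stated time of 1 h (a lower number here means that less compound is needed, a higher number that more compound is needed for the effect), compound 1 (`CCCCCCS(=O)(=O)/C=C/c1ccc(O)c(O)c1`) gives 7300 nM while compound 2 (`CCCCCS(=O)(=O)/C=C/c1ccc(O)c(O)c1`) gives 8100 nM and compound 3 (`O=S(=O)(/C=C/c1ccc(O)c(O)c1)CC1CCCCO1`) gives 10800 nM (all three within the scatter of one another). Compound 3 thus stands level with the other two: its steps are a 1.5-fold higher number from compound 1 to compound 3 (0.17 log units; within the scatter) and a 1.3-fold higher number from compound 2 to compound 3 (0.12 log units; within the scatter) and neither exceeds the scatter.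

Compound 4 (`CCCCCCCS(=O)(=O)/C=C/c1ccc(O)c(O)c1`) has hexyl in place of oxan-2-yl on a saturated chain carbon bound to a sulfonyl sulfur. The two steps above bear most directly on this change, since they exchange pentyl or butyl for oxan-2-yl at that place. The step of a 1.1-fold higher number from compound 1 to compound 2 (0.05 log units; within the scatter) with hydrogen in place of methyl on the chain also stays within the scatter.

Because a 1.5-fold higher number from compound 1 to compound 3 (0.17 log units; within the scatter) is small, no step beyond the scatter is expected in this assay for this change. The expected step is a 1.5-fold lower number from compound 3 to compound 4 (0.19 log units; within the scatter) and it remains within the scatter. Compound 4 is estimated at 7000 nM with an expected range of 3500 nM to 14000 nM (an estimate only).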

Compound 4, half-maximal effective concentration: 7100 nM
Beside the measured number, compound 4's estimate is 1.0-fold (0.01 log units) below it; low and high end bracket the measured number.
By their numbers in this assay, from the lowest: compounds 4, 1, 2 and 3 (each within the scatter of the next).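

In this assay, hexyl in place of oxan-2-yl on a saturated chain carbon bound to a sulfonyl sulfur gives a 1.5-fold lower number from compound 3 to compound 4 (0.18 log units; within the scatter), so at this place, with the heavy-atom count unchanged, losing the ring and its hydrogen-bond acceptor does not move the number beyond the scatter. The chain changes add a 1.1-fold lower number from compound 2 to compound 4 (0.06 log units; within the scatter) and a 1.0-fold lower number from compound 1 to compound 4 (0.01 log units; within the scatter), so all four compounds, three open-chain and one with the ring, remain within the scatter of one another. No supporting measurement is available to account for this flat picture.

Going by these compounds, it remains open whether an amine or a carboxylic acid on this chain, or a much longer chain, would give a step beyond the scatter. Also open, on these data alone, is how cyclohexyl in place of oxan-2-yl would compare.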